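The source may report more compounds than this note shows. Statements on the series, on what has been measured and on what is new or still open speak of the compounds shown alone.

Measured so far in a functional assay on RPMI-8226 cells (Homo sapiens) for cytotoxicity, read by MTT assay, with a stated time of 48 h; a lower number here means a stronger inhibitor, a higher number a weaker inhibitor:
Compound 1 `O=C(NN=C1C(Cl)=C(Cl)C(Cl)=C1Cl)c1ccccc1` gives 600 nM.
Compound 2 `O=C(c1ccccc1)N(N=C1C(Cl)=C(Cl)C(Cl)=C1Cl)C(=O)c1ccccc1` gives 800 nM.
Compound 3 `Cc1ccc(C(=O)N(N=C2C(Cl)=C(Cl)C(Cl)=C2Cl)C(=O)c2ccc(C)cc2)cc1` gives 500 nM.

Compound 1 stands second highest of the three numbers, with compound 3 nearest and compound 2 furthest; all three lie within the scatter of one another. Within the data shown here, the single one-place step, a 1.3-fold higher number from compound 1 to compound 2 (0.12 log units; within the scatter), concerns the amide-type nitrogen and is within the scatter.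

Compound 4 `CC(C)(C)C(=O)NN=C1C(Cl)=C(Cl)C(Cl)=C1Cl` differs from compound 1 in one place: tert-butyl in place of phenyl on a carbonyl carbon. Among the measured compounds shown here, no measured step touches this carbonyl substituent, so the measured steps give no direct guide; the series so far shows only changes within the scatter. Compound 4 is therefore expected to show no step beyond the scatter, a 1.2-fold higher number from compound 1 to compound 4 (0.07 log units; within the scatter), and is estimated at 700 nM with a range of 250 nM to 2000 nM.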

Compound 4, half-maximal inhibitory concentration: 90 nM
Beside the measured number, compound 4's estimate is 7.8-fold (0.89 log units) above it; the measured number lies below the stated range.
By their numbers in this assay, from the lowest: compound 4; then compounds 3, 1 and 2 (each within the scatter of the next).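

Among these compounds, the carbonyl substituent is the first place where a single change moves the number beyond the scatter: in this assay, tert-butyl in place of phenyl gives a 6.7-fold lower number from compound 1 to compound 4 (0.82 log units; beyond the scatter). Among the compounds shown here, the one step on the amide-type nitrogen, a 1.3-fold higher number from compound 1 to compound 2 (0.12 log units; within the scatter), showed no such response. Nothing available explains the step on the carbonyl carbon.

On these data alone, whether the lower number is specific to tert-butyl or extends to other groups at this place, such as isopropyl, cyclohexyl or a longer chain like n-butyl, remains open. Also open, as far as these compounds go, is whether an amine or a substituted phenyl on the carbonyl carbon would move the number.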